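Amide nitrogen substituents on the shared core

This account rests on a few compounds, and the source may have more. Where it says the series, first, only, none or still open, it means among the compounds named here.

Compound 1 `COc1ccc(NC(=O)c2cc(Oc3ccc(/C=C/c4ccccn4)cc3)ccn2)cc1` carries a 4-methoxyphenyl on the amide-type nitrogen of the shared core. In a functional assay on A549 cells (Homo sapiens) for antiproliferative activity, read by CCK-8 assay, with a stated time of 48 h (a lower number here means a stronger inhibitor, a higher number a weaker inhibitor), compound 1 gives 20000 nM, the lowest of the two numbers available. Compound 3 `CC(C)NC(=O)c1cc(Oc2ccc(/C=C/c3ccccn3)cc2)ccn1`, with isopropyl at that nitrogen, gives 21400 nM in this assay, and the step is a 1.1-fold higher number from compound 1 to compound 3 (0.03 log units; within the scatter). Compound 2 `O=C(NCc1ccc(F)cc1)c1cc(Oc2ccc(/C=C/c3ccccn3)cc2)ccn1` reaches only a limit in this assay, > 100000 nM; this is noted as the limit of > 100000 nM in this assay, at which 1 of the 3 values shown sits.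

The step to the benzyl-type amide is an at least 5.0-fold higher number from compound 1 to compound 2 (0.69 log units; beyond the scatter), and the step from that limit back to the small aliphatic amide is an at least 4.6-fold lower number from compound 2 to compound 3 (0.66 log units; beyond the scatter).

Compound 4 `O=C(NC1CCCCC1)c1cc(Oc2ccc(/C=C/c3ccccn3)cc2)ccn1` has not yet been measured. Its change from compound 1 is cyclohexyl in place of 4-methoxyphenyl on an amide-type nitrogen. Going by the values given here, of the measured steps, the exchange of 4-methoxyphenyl for an aliphatic group bears most directly on it, and that exchange gave a step within the scatter, while the only step beyond the scatter, toward 4-fluorobenzyl, went to weaker inhibition. A cyclohexyl is an aliphatic ring and is therefore expected to behave more like isopropyl than like 4-fluorobenzyl, so no step beyond the scatter is expected in this assay, with some lean toward a higher number. The expected step is a 1.4-fold higher number from compound 1 to compound 4 (0.13 log units; within the scatter). Compound 4 is estimated at 27000 nM in this assay, with a range of 10000 nM to 75000 nM.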

Compound 4, half-maximal inhibitory concentration: 12500 nM
Compound 4: the middle estimate sits 2.2-fold (0.33 log units) above what was measured; the measured number falls inside the stated range.
By their numbers in this assay, from the lowest: compounds 4, 1 and 3 (each within the scatter of the next). At a limit, above all of these: compound 2.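

In this assay, the exchange of the aromatic ring of 4-methoxyphenyl for the non-aromatic ring of cyclohexyl, which also removes a hydrogen-bond acceptor from the group, gives a 1.6-fold lower number from compound 1 to compound 4 (0.20 log units; within the scatter), and the exchange of isopropyl for cyclohexyl gives a 1.7-fold lower number from compound 3 to compound 4 (0.23 log units; within the scatter), so among compounds 1, 3 and 4 neither exchange moves the number beyond the scatter. The other comparison, an at least 8.0-fold lower number from compound 2 to compound 4 (0.90 log units; beyond the scatter), shows that a ring carried directly on the amide-type nitrogen can stand well clear of compound 2 whether it is aromatic, as in compound 1, or non-aromatic, as in compound 4, which ties the separation seen so far to the 4-fluorobenzyl amide alone. Compound 2 remains a limit rather than a number, so the true size of that separation stays unknown: the limit of > 100000 nM in this assay, at which 1 of the 4 values shown sits.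

The compounds shown leave open whether the loss at compound 2 belongs to the carbon link of the benzyl group or to its fluorine, since compound 2 differs from the others in both. A plain benzyl, a 4-fluorophenyl or a cyclohexylmethyl group would separate these, and a ring bearing an amine or a carboxylic acid would test whether this position can give a number beyond the scatter of compounds 1, 3 and 4.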